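Pyridinylmethyl amide swapped for a methylbenzyl amide

This account rests on a few compounds, and the source may have more. Where it says the series, first, only, none or still open, it means among the compounds named here.

Three measured compounds share one core and differ mainly at the amide end. Compound 1 `CC(C)c1c(C(=O)N2CCC[C@H](c3ccccc3)C2)nn(-c2ccc(F)cc2)c1CC[C@@H](O)C[C@@H](O)CC(=O)O` was tested in a functional assay on L6 cells (Rattus norvegicus) for inhibition (on this read-out lower numbers stand for stronger inhibition and higher numbers for weaker inhibition), and gave 310 nM. Compound 2 `CC(C)c1c(C(=O)N(C)Cc2ccccc2)nn(-c2ccc(F)cc2)c1OC[C@@H](O)C[C@@H](O)CC(=O)O` gives 6720 nM in this assay. Compound 3 `CC(C)c1c(C(=O)NCc2ccccn2)nn(-c2ccc(F)cc2)c1OC[C@@H](O)C[C@@H](O)CC(=O)O` stands as "not determined" (no result reported) in this assay, since no result was reported for it; it therefore stands nowhere on the scale that compounds 1 and 2 occupy, and nothing can be said about how it compares with either of them.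

The step from compound 3 to compound 4 `Cc1cccc(CN(C)C(=O)c2nn(-c3ccc(F)cc3)c(OC[C@@H](O)C[C@@H](O)CC(=O)O)c2C(C)C)c1` is a change at the amide: methyl(3-methylbenzyl)amino in place of ((pyridin-2-yl)methyl)amino on a carbonyl carbon. A hydrogen-bond donor and a hydrogen-bond acceptor leave with the group, and the ring that enters is built of carbon only.

Among the measured compounds shown here, no measured pair shows this exact step, so its size in this assay cannot be read from a measurement, and compound 3 itself gives no starting point. The closest measured relative of compound 4 is compound 2, and because compound 2 gives 6720 nM in this assay, a weak result of similar size is expected. Compound 4 is expected to give roughly 5000 nM in this assay, with a likely range from 1500 nM to 15000 nM.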

Compound 4, half-maximal inhibitory concentration: 18500 nM
Compound 4: the middle estimate sits 3.7-fold (0.57 log units) below what was measured; the whole stated range lies below it.
By their numbers in this assay, from the lowest: compound 1; then compound 2; then compound 4.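

Compound 3 has no reported result, so its step to compound 4 cannot be read; the comparison that can be read is with compound 2, which differs from compound 4 in one place only, a methyl in place of hydrogen on an aromatic carbon of the benzyl ring. In this assay, that single small addition gives a 2.8-fold higher number from compound 2 to compound 4 (0.44 log units; beyond the scatter), a modest step but one beyond the scatter, which shows for this pair that the amide end of the molecule responds to a change as small as one methyl, and that here the response is toward weaker inhibition. Nothing available explains why the number rises with this methyl.

The compounds shown leave open whether this rise belongs to the methyl itself or would also appear with a fluorine, a chlorine or a methoxy group on the same ring carbon. Among the compounds shown here, they also leave open how the ((pyridin-2-yl)methyl)amino group compares with the carbon-only ring in this assay, as the one compound carrying it has no number to set beside the others.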